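The source may report more compounds than this note shows. Statements on the series, on what has been measured and on what is new or still open speak of the compounds shown alone.

Measured in a functional assay on isolated protein for inhibition of Glucose-dependent insulinotropic receptor (Rattus norvegicus), read by HTRF and cAMP accumulation; a higher number here means that more compound is needed for the effect, a lower number that less compound is needed:
Compound 1 `Cc1nc(S(C)(=O)=O)ccc1Oc1ncnc(OC2CCN(C(=O)OC(C)(C)C(F)(F)F)CC2)c1F` gives 47.2 nM
Compound 2 `Cc1nc(S(C)(=O)=O)ccc1Oc1ncnc(OC2CCN(C(=O)C(C)(F)F)CC2)c1F` gives 239 nM

Compound 2 has the highest of these two numbers; its nearest neighbour is compound 1, with a 5.1-fold higher number from compound 1 to compound 2 (0.70 log units; beyond the scatter). Compound 3 `Cc1nc(S(C)(=O)=O)ccc1Oc1ncnc(OC2CCN(C(=O)C3CCCC3)CC2)c1F` differs from compound 2 by cyclopentyl in place of 1,1-difluoroethyl on a carbonyl carbon. Among the compounds with values here, the only measured step alters a different group on that same carbonyl carbon, so nothing measured bears directly on swapping the fluorinated chain for a carbon ring. Compound 3 is therefore expected to show at most a small shift, a 1.8-fold lower number from compound 2 to compound 3 (0.26 log units; within the scatter). In this assay compound 3 is estimated at 130 nM, with a range from 30 nM to 500 nM.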

Compound 3, half-maximal effective concentration: 407 nM
Estimate against measurement, compound 3: 3.1-fold (0.50 log units) below; the range from low to high includes it.
By their numbers in this assay, from the lowest: compound 1; then compounds 2 and 3 (each within the scatter of the next).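

In this assay, placing cyclopentyl instead of 1,1-difluoroethyl on the carbonyl carbon gives a small step (a 1.7-fold higher number from compound 2 to compound 3 (0.23 log units; within the scatter)), so these compounds do not separate the carbon ring from the fluorinated chain. Compound 3 stays apart from compound 1 (an 8.6-fold higher number from compound 1 to compound 3 (0.94 log units; beyond the scatter)), as compound 2 does. No accompanying measurement explains these numbers. Still open, on these data alone, is whether the gap to compound 1 follows the oxygen attached to its carbonyl carbon or its trifluoromethyl group. A cyclopentyloxy or plain tert-butoxy group at this position would test that.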